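This account rests on a few compounds, and the source may have more. Where it says the series, first, only, none or still open, it means among the compounds named here.

Compound 1 `CCCCCC(=O)N(NC(=O)c1cc(C)cc(C)c1)C(C)(C)C` and compound 2 `Cc1cc(C)cc(C(=O)NN(C(=O)CCC(C)C)C(C)(C)C)c1` share a core, and compound 2 carries isopropyl in place of propyl on a saturated chain carbon, two bonds along the chain from a carbonyl carbon. In an assay on cells for agonist activity at ecdysone receptor (Bombyx mori), read by a luciferase reporter, with a stated time of 24 h (a lower number here means that less compound is needed, a higher number that more compound is needed for the effect), compound 1 gives 8710 nM, while compound 2 gives 14500 nM, so the change made a 1.7-fold higher number from compound 1 to compound 2 (0.22 log units; within the scatter). Compound 3 `CCCCN(NC(=O)c1ccccc1)C(=O)c1ccccc1` rests on a different core; how the two cores differ is not broken down here. In this assay compound 3 gives 7080 nM. Compound 4 `CC(C)CN(NC(=O)c1ccccc1)C(=O)c1ccccc1` differs from compound 3 by isopropyl in place of propyl on a saturated chain carbon bound to an amide-type nitrogen. This is the same kind of change as from compound 1 to compound 2, but the place is not the same: there the carbon is two bonds along the chain from a carbonyl carbon, here it is bound to an amide-type nitrogen. The step from compound 3 to compound 4 is expected to be small, a 1.3-fold higher number from compound 3 to compound 4 (0.13 log units; within the scatter), because the earlier change gave a 1.7-fold higher number from compound 1 to compound 2 (0.22 log units; within the scatter). Compound 4 is therefore estimated at 9500 nM, between 3500 nM and 26000 nM.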

Compound 4, half-maximal effective concentration: 2880 nM
For compound 4 the middle estimate is 3.3-fold (0.52 log units) above the measured one; measured number outside the range, below it.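

In this assay the change gives a 2.5-fold lower number from compound 3 to compound 4 (0.39 log units; beyond the scatter) on the core of compound 3, a step beyond the scatter, whereas on the core of compound 1 the same kind of change stayed within it. The two steps do not agree: the same change on two cores in this assay, a 1.7-fold higher number (0.22 log units; within the scatter) from compound 1 to compound 2 and a 2.5-fold lower number (0.39 log units; beyond the scatter) from compound 3 to compound 4, 4.1-fold (0.61 log units) apart, beyond the scatter of two such steps. This shows that the step seen on one core did not carry over to the other here, but with a single pair on each core and the change at a different place in each, it does not show whether the core or the place sets the outcome.

As far as these compounds go, it remains open how a longer chain or an amine in place of the butyl of compound 3 would read in this assay.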